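Removing (phenylsulfonyl)amino: from compound 3 to compound 4

This account rests on a few compounds, and the source may have more. Where it says the series, first, only, none or still open, it means among the compounds named here.

Values measured in a functional assay for inhibition, with Homo sapiens as the target (on this read-out higher numbers stand for weaker inhibition and lower numbers for stronger inhibition), are as follows:
Compound 1 `O=C(NC[C@H](NS(=O)(=O)c1cccnc1)C(=O)O)c1cc2cc(CCCC3CCNCC3)sc2s1` gives 21 nM
Compound 2 `O=C(NC[C@H](NS(=O)(=O)c1cccs1)C(=O)O)c1cc2cc(CCC3CCNCC3)sc2s1` gives 9 nM
Compound 3 `O=C(NC[C@H](NS(=O)(=O)c1ccccc1)C(=O)O)c1cc2cc(CCC3CCNCC3)sc2s1` gives 8 nM

Compound 3 and compound 2 stand together at the low end of the three numbers in this assay and lie within the scatter of each other. Compound 1 gives a higher number than compound 3, and that gap lies beyond the scatter.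

The next compound is compound 4 `O=C(O)CCNC(=O)c1cc2cc(CCC3CCNCC3)sc2s1` and its change is a large one (hydrogen in place of (phenylsulfonyl)amino on a saturated chain carbon bound to a carbonyl carbon and a saturated chain carbon). Hydrogen comes in place of (phenylsulfonyl)amino on a saturated chain carbon bound to a carbonyl carbon and a saturated chain carbon.

For the measured compounds named here, only one measured step bears on this part of the structure. It is a 1.1-fold lower number from compound 2 to compound 3 (0.05 log units; within the scatter) with phenyl in place of thiophen-2-yl on a sulfonyl sulfur, and it stays within the scatter. That step exchanges only the ring and keeps the sulfonyl group. No measured compound lacks the whole group, so the size of this change is not shown directly.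

Losing the whole group is expected to move the number upward, towards weaker inhibition, beyond the scatter. The expected move is a 7.5-fold higher number from compound 3 to compound 4 (0.88 log units; beyond the scatter) and this estimate is uncertain. For compound 4 the estimated value is 60 nM with an expected range from 15 nM to 250 nM in this assay.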

Compound 4, half-maximal inhibitory concentration: 410 nM
Estimate against measurement, compound 4: 6.8-fold (0.83 log units) below; the whole stated range lies below it.
By their numbers in this assay, from the lowest: compounds 3 and 2 (each within the scatter of the next); then compound 1; then compound 4.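

In this assay, the position on the saturated chain carbon bound to a carbonyl carbon and a saturated chain carbon proves far less tolerant of losing the whole substituent than of exchanging its ring: removing the substituent gives large steps beyond the scatter (a 51-fold higher number from compound 3 to compound 4 (1.71 log units; beyond the scatter); a 46-fold higher number from compound 2 to compound 4 (1.66 log units; beyond the scatter)), whereas the exchange of thiophen-2-yl for phenyl stays within the scatter (a 1.1-fold lower number from compound 2 to compound 3 (0.05 log units; within the scatter)). Among these compounds, the sulfonylamino unit therefore matters far more at this position than the choice between those two rings, although compound 4 still gives a finite value of 410 nM without it. No measurement available here explains the size of this loss.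

The compounds shown leave open which part of the departing group accounts for the difference, since a plain amine, an acetylamino group or a benzoylamino group at this carbon would separate the nitrogen from the sulfonyl and the ring. As far as these compounds go, it also remains open whether a methylsulfonylamino group, which has a sulfonyl but no ring, would stay close to compound 3 or fall towards compound 4.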